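This account rests on a few compounds, and the source may have more. Where it says the series, first, only, none or still open, it means among the compounds named here.

Compound 1 `CC(Oc1ccccc1C=O)C1=NCCN1` is measured in a functional assay on CHO cells for agonist activity at Alpha-2C adrenergic receptor (Homo sapiens) (on this read-out lower numbers stand for an effect already at smaller amounts and higher numbers for an effect only at larger amounts of compound), where compound 1 gives 100 nM. Compound 2 `CC(C)Oc1ccccc1OC(C)C1=NCCN1` gives 100 nM in this assay, and compound 3 `C=COc1ccccc1OC(C)C1=NCCN1` gives 631 nM. Compound 1 therefore stands level with compound 2 at the digits shown, the two together at the lowest numbers of the three, with compound 3 furthest away: a 6.3-fold higher number from compound 1 to compound 3 (0.80 log units; beyond the scatter).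

Compound 4 `CC(Oc1ccccc1Br)C1=NCCN1` differs from compound 1 by one change: bromo in place of formyl on an aromatic carbon. Among the measured compounds shown here, no measured step involves bromo, so the bearing steps are the two that also exchange the formyl group for something else. One of them, no change at the digits printed from compound 1 to compound 2 (within the scatter), changes nothing beyond the scatter; the other, a 6.3-fold higher number from compound 1 to compound 3 (0.80 log units; beyond the scatter), is a modest rise. Replacing formyl has thus given either no shift or a modest weakening, and nothing in this set shows a fall. The expected step for compound 4 is therefore a 1.3-fold higher number from compound 1 to compound 4 (0.11 log units; within the scatter), a number close to that of compound 1 with the range tilted toward higher values. Compound 4 is estimated at 130 nM in this assay, between 30 nM and 600 nM.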

Compound 4, half-maximal effective concentration: 10 nM
For compound 4 the middle estimate is 13-fold (1.11 log units) above the measured one; the whole stated range lies above it.
By their numbers in this assay, from the lowest: compound 4; then compounds 1 and 2 (each within the scatter of the next); then compound 3.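

In this assay the aromatic carbon that had carried formyl, isopropoxy or vinyloxy had shown nothing lower than the level of compound 1, yet bromo takes the number down beyond the scatter (a 10-fold lower number from compound 1 to compound 4 (1.00 log units; beyond the scatter)) and does the same against isopropoxy (a 10-fold lower number from compound 2 to compound 4 (1.00 log units; beyond the scatter)). The largest gap is against vinyloxy (a 63-fold lower number from compound 3 to compound 4 (1.80 log units; beyond the scatter)), so this position can move the number in both directions, and a single bromine atom with no hydrogen-bond acceptor gives the lowest number of the four compounds. Nothing measured here accounts for this drop.

The compounds shown leave open whether the lower number belongs to bromo in particular or would also come with chloro, methyl or an amine on this aromatic carbon. They also leave open whether bromo would give the same result on another carbon of the ring.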